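Cytotoxicity outlook when 2-phenylethenyl replaces 2-methoxyphenyl

A few compounds are considered here, and "the series" means these few. Any claim that something is new, unique, unknown or untested is made for them only; others in the source may bear on it.

Compound 1 `O=C(c1ccncc1)N1N=C(c2cc3ccccc3o2)CC1c1ccccc1O` and compound 2 `COc1ccccc1C1CC(c2cc3ccccc3o2)=NN1C(=O)c1ccncc1` share one core and differ only by a methyl in place of hydrogen on an oxygen on an aromatic ring. In an ADME assay on Vero cells (Chlorocebus sabaeus) for cytotoxicity, read by MTT assay, with a stated time of 72 h (on this read-out lower numbers stand for stronger inhibition and higher numbers for weaker inhibition), compound 1 reaches only the limit > 195000 nM. In this assay compound 2 also reaches only the limit > 202000 nM. The step that the two limits leave unreadable from compound 1 to compound 2 cannot be read because the limit of > 195000 nM in this assay, at which 1 of the 2 values shown sits, and the limit of > 202000 nM in this assay, at which 1 of the 2 values shown sits, mark where both values stop.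

Compound 3 `O=C(c1ccncc1)N1N=C(c2cc3ccccc3o2)CC1/C=C/c1ccccc1` carries the change (2-phenylethenyl in place of 2-methoxyphenyl on a saturated ring carbon). No measured step touches this change, and the single measured step in this assay is itself unreadable, so the shown numbers give no reason to expect a readable step in either direction. Compound 3 is therefore expected to sit near 200000 nM in this assay, within a range from 100000 nM to 400000 nM. The estimated step is a number no higher from compound 2 to compound 3 (the limit leaves the size open), and most likely the assay will again report only a limit.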

Compound 3, half-maximal inhibitory concentration: > 212000 nM
Compound 3 ended at the assay's limit (the forecaster's own chance of this, stated with the estimate: 80%); at least 1.0-fold (0.02 log units) between middle value and limit.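

In this assay, for the compounds shown here, compound 1, compound 2 and compound 3 all end at a limit of the assay and not at a number, so no step among them can be read. The compounds shown leave open whether any of these changes on the shared core shifts cytotoxicity at all.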